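A Shorter Side Chain With a Double Bond

The compounds below may be only part of what the source reports. "The series", "measured", "known", "first", "only" and "open" are said of these compounds alone.

Of the compounds shown here, three have numbers so far in a functional assay on MCF7 cells (Homo sapiens) for inhibition, read by colorimetric assay and MTT assay, with a stated time of 72 h (on this read-out lower numbers stand for stronger inhibition and higher numbers for weaker inhibition), and all three sit close together. Compound 1 (`Cn1c2cnc1OCCCCCCCCCCOc1cc3ccccc3cc1-2`) gives 24000 nM and compound 2 (`Cn1c2cnc1OCCCCCCCCCCOc1ccccc1-2`) gives 24000 nM in this test. Compound 3 (`CCCCCCOc1ncc(-c2ccccc2OC)n1C`), which carries an open hexyloxy chain, gives 27000 nM and so stands level with both others, within the scatter of repeated measurements.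

Compound 4 (`C=CCCOc1ncc(-c2ccccc2OC)n1C`) alters that chain: vinyl in place of butyl on a saturated chain carbon, two bonds along the chain from an oxygen on an aromatic ring with vinyl in place of butyl on a saturated chain carbon, two bonds along the chain from an oxygen on an aromatic ring. Hexyloxy thus becomes (but-3-en-1-yl)oxy.

Among the compounds with values here, no measured pair isolates this change. Still, compound 2 at 24000 nM and compound 3 at 27000 nM match despite their different structures, so no step beyond the scatter is expected in this assay here. The expected 1.1-fold higher number from compound 3 to compound 4 (0.05 log units; within the scatter) is therefore small. For compound 4 the estimated value is 30000 nM within an expected range from 15000 nM to 60000 nM in this assay.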

Compound 4, half-maximal inhibitory concentration: 27000 nM
For compound 4 the middle estimate is 1.1-fold (0.05 log units) above the measured one; measured number inside the range.
By their numbers in this assay, from the lowest: compounds 1, 2, 3 and 4 (each within the scatter of the next).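

Putting vinyl in place of butyl on a saturated chain carbon, two bonds along the chain from an oxygen on an aromatic ring, brings no change at the digits printed from compound 3 to compound 4 (within the scatter) in this assay. Within the data shown here, this is the first comparison here between compounds that differ in only one place, and it shows that hexyloxy can give way to (but-3-en-1-yl)oxy, a shorter chain ending in a double bond, without a step beyond the scatter. No measured information on why the number holds steady is available.

The step shortens the chain and adds the double bond together, so the compounds shown do not separate the two changes. From the compounds shown here alone, how the number would respond to an amine or a carboxylic acid at this place on the chain also stays open.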